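Changing the Outer Aryl Group in a Cytotoxicity Series

The source may report more compounds than this note shows. Statements on the series, on what has been measured and on what is new or still open speak of the compounds shown alone.

Measured compounds:
compound 1, `Cc1cc(-c2ccc(F)cc2)cc(C)c1Nc1ccnc(Nc2ccc(C#N)cc2)n1`, 4170 nM
compound 2, `Cc1cc(-c2ccccc2C(F)(F)F)cc(C)c1Nc1ccnc(Nc2ccc(C#N)cc2)n1`, 4210 nM
compound 3, `Cc1cc(-c2cc(F)cc(F)c2)cc(C)c1Nc1ccnc(Nc2ccc(C#N)cc2)n1`, 3910 nM

These three compounds share one core and differ only in the aryl group attached to it. In an ADME assay on MT4 cells (Homo sapiens) for cytotoxicity, read by MTT assay, with a stated time of 4 days (a lower number here means that less compound is tolerated, a higher number that more compound is tolerated), compound 3 sits alongside the other two: a 1.1-fold lower number from compound 1 to compound 3 (0.03 log units; within the scatter), and a 1.1-fold lower number from compound 2 to compound 3 (0.03 log units; within the scatter). The remaining pair behaves the same way, with a 1.0-fold higher number from compound 1 to compound 2 (0.00 log units; within the scatter). So, across the three aryl groups tried, this assay has not moved beyond its scatter.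

Compound 4, `Cc1ccccc1-c1cc(C)c(Nc2ccnc(Nc3ccc(C#N)cc3)n2)c(C)c1`, has not yet been measured. It differs from compound 3 in one place: 2-methylphenyl in place of 3,5-difluorophenyl on an aromatic carbon. All three measured steps change the same aryl group and all are within the scatter, which argues that this further exchange will also leave this assay where it is. Compound 4 is therefore expected to give about 4000 nM, with a likely range from 2000 nM to 8000 nM. The expected step is a 1.0-fold higher number from compound 3 to compound 4 (0.01 log units; within the scatter), that is, none beyond the scatter.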

Compound 4, half-maximal cytotoxic concentration: 3820 nM
Compound 4: middle estimate off by 1.0-fold (0.02 log units), on the high side; the range from low to high includes it.
By their numbers in this assay, from the lowest: compounds 4, 3, 1 and 2 (each within the scatter of the next).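

Compound 4 is the only one of the four whose outer aryl group carries no fluorine, yet in this assay the exchange of 3,5-difluorophenyl for 2-methylphenyl gives a 1.0-fold lower number from compound 3 to compound 4 (0.01 log units; within the scatter). The most direct comparison, methyl in place of trifluoromethyl, gives a 1.1-fold lower number from compound 2 to compound 4 (0.04 log units; within the scatter), and the exchange of 4-fluorophenyl for 2-methylphenyl gives a 1.1-fold lower number from compound 1 to compound 4 (0.04 log units; within the scatter), so across these four aryl groups the presence of fluorine makes no difference beyond the scatter in this assay. Nothing available explains this flat result.

All four groups are six-membered carbon rings bearing only fluorine, trifluoromethyl or methyl. As far as these compounds go, whether an amine or a carboxylic acid on that ring, or a longer chain in its place, would shift the reading remains open.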